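The source may report more compounds than this note shows. Statements on the series, on what has been measured and on what is new or still open speak of the compounds shown alone.

Compound 1 `COc1ccccc1-c1cc(C2CCN(C)C2)ccc1Cl` sets the strongest mark in this group: in an assay on isolated protein for binding affinity to 5-hydroxytryptamine receptor 1D (Homo sapiens) (on this read-out lower numbers stand for stronger inhibition and higher numbers for weaker inhibition), compound 1 gives 19 nM. Compound 2 `COc1ccccc1-c1cc(CN(C)C)ccc1Cl` carries a (dimethylamino)methyl group in place of the 1-methylpyrrolidin-3-yl, and in this assay compound 2 gives 1300 nM, a step of a 68-fold higher number from compound 1 to compound 2 (1.84 log units; beyond the scatter). Compound 3 `CCN(CC)Cc1ccc(Cl)c(-c2ccccc2OC)c1` goes one step further. For compound 3 this assay reports only a limit, > 10000 nM, and so compound 3 stands at the limit of > 10000 nM in this assay, at which 1 of the 3 values shown sits; the step of an at least 7.6-fold higher number from compound 2 to compound 3 (0.88 log units; beyond the scatter) is therefore known only as a lower bound, and compound 3 is the weakest binder among the three measured.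

Compound 4 `CCCNCc1ccc(Cl)c(-c2ccccc2OC)c1` differs from compound 3 by propylamino in place of diethylamino on a saturated chain carbon bound to an aromatic carbon. Among the measured compounds shown here, the only measured step that touches the same place is an at least 7.6-fold higher number from compound 2 to compound 3 (0.88 log units; beyond the scatter), which shows that enlarging the amine from dimethyl to diethyl costs binding. Compound 4 takes a route in between, with one fewer heavy atom than diethylamino and a hydrogen-bond donor that diethylamino lacks, so in this assay compound 4 is expected to recover some binding, an estimated at least 2.0-fold lower number from compound 3 to compound 4 (0.30 log units; that floor lies within the scatter). Compound 4 is thus estimated at 5000 nM, within 1000 nM to 20000 nM.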

Compound 4, inhibition constant: 220 nM
The estimate for compound 4 lay 23-fold (1.36 log units) above the measured number; measured number below the stated range.
By their numbers in this assay, from the lowest: compound 1; then compound 4; then compound 2. At a limit, above all of these: compound 3.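

Read in this assay, the amine at this place follows no simple trend with size: an at least 45-fold lower number from compound 3 to compound 4 (1.65 log units; beyond the scatter), and a 5.9-fold lower number from compound 2 to compound 4 (0.77 log units; beyond the scatter), so propylamino beats both diethylamino and dimethylamino here. Compound 3 sits at a limit of the assay, so the first of these steps is only a floor: the limit of > 10000 nM in this assay, at which 1 of the 4 values shown sits. Even so, (propylamino)methyl does not match the 1-methylpyrrolidin-3-yl group, with a 12-fold higher number from compound 1 to compound 4 (1.06 log units; beyond the scatter).

The compounds shown leave open whether the gain with propylamino goes with the hydrogen on its nitrogen or with the propyl chain itself. Methylamino, ethylamino and butylamino at the same place, together with the tertiary N-methyl-N-propylamino group, would help to separate these two readings.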